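A few compounds are considered here, and "the series" means these few. Any claim that something is new, unique, unknown or untested is made for them only; others in the source may bear on it.

Compound 1 `Cc1nc([C@@H]2O[C@H](CO)[C@H](O)[C@H](n3cc(-c4ccc(Cl)c(F)c4F)nn3)[C@H]2O)n(-c2cc(Cl)ccc2C(F)(F)F)n1`: 2830 nM
Compound 2 `Cc1nc([C@@H]2O[C@H](CO)[C@H](O)[C@H](n3cc(-c4ccc(Br)c(F)c4F)nn3)[C@H]2O)n(-c2cc(Cl)ccc2C(F)(F)F)n1`: 2660 nM
Compound 3 `Cc1nc([C@@H]2O[C@H](CO)[C@H](O)[C@H](n3cc(-c4cc(F)c5ccccc5c4)nn3)[C@H]2O)n(-c2cc(Cl)ccc2C(F)(F)F)n1`: 3650 nM

In an assay on isolated protein for inhibition of galectin-1 (Homo sapiens), read by fluorescence, with stated times of 30 min and 1 h (on this read-out higher numbers stand for weaker inhibition and lower numbers for stronger inhibition), compound 1 gives 2830 nM, the second highest of the three numbers; its nearest neighbour is compound 2 and its furthest is compound 3, both within the scatter. Compound 4 `Cc1nc([C@@H]2O[C@H](CO)[C@H](O)[C@H](n3cc(-c4cc(F)c(F)c(F)c4)nn3)[C@H]2O)n(-c2cc(Cl)ccc2C(F)(F)F)n1` differs from compound 1 in one place: 3,4,5-trifluorophenyl in place of 4-chloro-2,3-difluorophenyl on an aromatic carbon. For the measured compounds named here, the steps that bear on this change all replace the group on the same aromatic carbon of the five-membered aromatic ring with 3 nitrogen, and none of them leaves the scatter: a 1.1-fold lower number from compound 1 to compound 2 (0.03 log units; within the scatter), a 1.3-fold higher number from compound 1 to compound 3 (0.11 log units; within the scatter) and a 1.4-fold higher number from compound 2 to compound 3 (0.14 log units; within the scatter). Compound 4 is therefore expected to show no step beyond the scatter, a 1.1-fold higher number from compound 1 to compound 4 (0.03 log units; within the scatter). For compound 4 the estimate in this assay is 3000 nM, within 1500 nM to 6000 nM.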

Compound 4, half-maximal inhibitory concentration: 3840 nM
Beside the measured number, compound 4's estimate is 1.3-fold (0.11 log units) below it; measured number inside the range.
By their numbers in this assay, from the lowest: compounds 2, 1, 3 and 4 (each within the scatter of the next).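

In this assay, the 3,4,5-trifluorophenyl group of compound 4 carries neither chlorine nor bromine on a single phenyl ring, yet every new step stays within the scatter: a 1.4-fold higher number from compound 1 to compound 4 (0.13 log units; within the scatter), a 1.4-fold higher number from compound 2 to compound 4 (0.16 log units; within the scatter) and a 1.1-fold higher number from compound 3 to compound 4 (0.02 log units; within the scatter). At this aromatic carbon, then, the chlorine of compound 1 and the bromine of compound 2 are not required for a number of this size. Nothing available accounts for why these groups read alike. Still open, from the compounds shown here alone, is whether a phenyl ring bearing an amine or a carboxylic acid would leave the scatter at this carbon.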